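Swapping methylamino for morpholin-4-yl on a carbonyl carbon

This account rests on a few compounds, and the source may have more. Where it says the series, first, only, none or still open, it means among the compounds named here.

Measured in an in vitro ADME assay on microsomes from liver (Macaca fascicularis) for metabolic stability (on this read-out lower numbers stand for slow clearance and higher numbers for fast clearance), so far
- compound 1 `CC[C@H](C)[C@@H]1C(=O)N[C@H](C2Cc3ccccc3C2)C(=O)N1[C@@H](C(=O)N1CCOCC1)c1cnc(C)cc1C` gives 16 mL.min-1.g-1
- compound 2 `CCC(CC)[C@@H]1C(=O)N[C@H](C2Cc3ccccc3C2)C(=O)N1[C@@H](C(=O)N1CCOCC1)c1ccc(C)nc1` gives 18 mL.min-1.g-1
- compound 3 `CCC(CC)[C@@H]1C(=O)N[C@H](C2Cc3ccccc3C2)C(=O)N1[C@@H](C(=O)NC)c1ccc(C)nc1C` gives 31 mL.min-1.g-1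

Compound 3 stands within the usual scatter of both compound 1 and compound 2, so these three values in this assay do not separate from one another. The next structure, compound 4 `CCC(CC)[C@@H]1C(=O)N[C@H](C2Cc3ccccc3C2)C(=O)N1[C@@H](C(=O)N1CCOCC1)c1ccc(C)nc1C`, has morpholin-4-yl in place of methylamino on a carbonyl carbon and otherwise matches compound 3. Going by the values given here, no measured pair shows this change alone, so no direct step is available. Among the compounds with values here, compound 1 and compound 2 do carry morpholin-4-yl at that carbonyl carbon, although they differ from compound 4 elsewhere, and their values are the only guide. The estimate is a step of modest size toward a lower number (a 1.5-fold lower number from compound 3 to compound 4 (0.17 log units; within the scatter)), not beyond the scatter. For compound 4 the expected value is 21 mL.min-1.g-1 in this assay, with an estimated range (11 mL.min-1.g-1 to 40 mL.min-1.g-1).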

Compound 4, intrinsic clearance in microsomes: 14 mL.min-1.g-1
Compound 4: the middle estimate sits 1.5-fold (0.18 log units) above what was measured, and the stated range covers the measured number.
By their numbers in this assay, from the lowest: compounds 4, 1, 2 and 3 (each within the scatter of the next, the first and the last beyond it).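

In this assay the change of methylamino to morpholin-4-yl on a carbonyl carbon can now be read alone, and a 2.2-fold lower number from compound 3 to compound 4 (0.35 log units; beyond the scatter) is modest but lies beyond the scatter, which none of the earlier values could show. By contrast, methyl in place of hydrogen on an aromatic carbon gives a 1.3-fold lower number from compound 2 to compound 4 (0.11 log units; within the scatter) and so does not separate the two compounds in this read-out. The compounds shown offer no measurement that explains either step.

Going by these compounds, this morpholin-4-yl change rests on a single pair, so it remains open whether it would hold with other groups elsewhere on the shared core. Also open, on these data alone, is how dimethylamino, piperidin-1-yl or a primary amide nitrogen bearing only hydrogens would read on that carbonyl carbon.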